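Bromo to cyano on an aromatic carbon

The source may report more compounds than this note shows. Statements on the series, on what has been measured and on what is new or still open speak of the compounds shown alone.

Compound 1 `COc1cccc([C@@H]2[C@H](Oc3ccccc3)C(=O)N2c2cc(OC)c(OC)c(OC)c2)c1` gives 171000 nM
Compound 2 `COc1cc(N2C(=O)[C@@H](Oc3ccccc3)[C@H]2c2ccc(Br)cc2)cc(OC)c1OC` gives 48000 nM

In a functional assay on MCF7 cells (Homo sapiens) for antiproliferative activity, read by MTT assay, with stated times of 24 h and 72 h (a higher number here means a weaker inhibitor, a lower number a stronger inhibitor), compound 2 has the lower of the two numbers, which makes it the stronger inhibitor of this pair. Compound 3 `COc1cc(N2C(=O)[C@@H](Oc3ccccc3)[C@H]2c2ccc(C#N)cc2)cc(OC)c1OC` has cyano in place of bromo on an aromatic carbon and is otherwise the same as compound 2. Among the measured compounds shown here, the only measured step on this aromatic group is a 3.6-fold lower number from compound 1 to compound 2 (0.55 log units; beyond the scatter) and it suggests a modest step at most in this assay for this change. For the measured compounds named here, no measured compound carries cyano, so the direction is uncertain, with a slight lean towards a higher number. The expected step is a 1.3-fold higher number from compound 2 to compound 3 (0.10 log units; within the scatter) and it is only an estimate. Compound 3 is estimated at 60000 nM and expected within 20000 nM to 170000 nM when measured.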

Compound 3, half-maximal inhibitory concentration: 31600 nM
Compound 3: the middle estimate sits 1.9-fold (0.28 log units) above what was measured; measured number inside the range.
By their numbers in this assay, from the lowest: compounds 3 and 2 (each within the scatter of the next); then compound 1.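

In this assay the change from 4-bromophenyl to 4-cyanophenyl gives a 1.5-fold lower number from compound 2 to compound 3 (0.18 log units; within the scatter) and so leaves the number essentially unchanged, which means bromo and cyano cannot be told apart at this position. The other comparison gives a 5.4-fold lower number from compound 1 to compound 3 (0.73 log units; beyond the scatter) and shows that compound 3, like compound 2, stands clear of compound 1. Nothing available explains these results.

Going by these compounds, whether an amine or a carboxylic acid on the same aromatic carbon would match bromo and cyano remains open.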